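Adding a Second Ring Nitrogen to the Side Ring

A few compounds are considered here, and "the series" means these few. Any claim that something is new, unique, unknown or untested is made for them only; others in the source may bear on it.

Compound 3 `Cc1cc(C#N)cc(C)c1Oc1nc(Nc2ccc(C#N)cc2)ncc1-c1cccnc1` shares its core with compound 1 `Cc1cc(C#N)cc(C)c1Oc1nc(Nc2ccc(C#N)cc2)ncc1-c1ccccc1` and compound 2 `Cc1cc(C#N)cc(C)c1Oc1nc(Nc2ccc(C#N)cc2)ncc1-c1ccco1`. In an ADME assay on MT4 cells (Homo sapiens) for cytotoxicity, read by MTT assay, with a stated time of 5 days (a higher number here means that more compound is tolerated, a lower number that less compound is tolerated), compound 1 gives 31800 nM and compound 3 gives 13500 nM, the lowest of the two numbers. In this assay compound 2 reaches only a limit, > 306000 nM. Compound 4 `Cc1cc(C#N)cc(C)c1Oc1nc(Nc2ccc(C#N)cc2)ncc1-c1cncnc1` differs from compound 3 in one place: pyrimidin-5-yl in place of pyridin-3-yl on an aromatic carbon. Two measured steps at the same place bear on it: a 2.4-fold lower number from compound 1 to compound 3 (0.37 log units; beyond the scatter), and an at least 9.6-fold higher number from compound 1 to compound 2 (0.98 log units; beyond the scatter). The present change is smaller than either of those, so a step of a 1.4-fold lower number from compound 3 to compound 4 (0.13 log units; within the scatter) is expected, within the scatter or slightly lower. Compound 4 is therefore expected to give about 10000 nM, between 4000 nM and 30000 nM.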

Compound 4, half-maximal cytotoxic concentration: > 298000 nM
Compound 4 gave a limit, no number (the forecaster's own chance of this, stated with the estimate: 5%); middle value at least 29-fold (1.47 log units) away from the limit.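

In this assay, pyrimidin-5-yl in place of pyridin-3-yl gives an at least 22-fold higher number from compound 3 to compound 4 (1.34 log units; beyond the scatter), so a second ring nitrogen in this side ring does not simply extend what the first one did. Measured against phenyl, the pyrimidin-5-yl ring gives an at least 9.3-fold higher number from compound 1 to compound 4 (0.97 log units; beyond the scatter), while compound 3 lies on the lower side of compound 1. The result for compound 4 is a limit, not a number, and the step between compound 2 and compound 4 cannot be read.

As far as these compounds go, how far the true value of compound 4 lies beyond its limit stays open. Also open, from the compounds shown here alone, is whether an amine or a carboxylic acid on the pyrimidin-5-yl ring would give a similar result.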